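The compounds below may be only part of what the source reports. "The series", "measured", "known", "first", "only" and "open" are said of these compounds alone.

Working notes on the series. The shared core is that of compound 1 `COc1ccccc1NC(=O)N[C@H]1CC[C@H](Oc2ccc(F)cc2)CC1`, and the three measured analogues differ only in the group carried on the amide-type nitrogen. In a functional assay on CRL2813 cells (Homo sapiens) for cytotoxicity, read by sulforhodamine B assay, with a stated time of 5 days (a higher number here means a weaker inhibitor, a lower number a stronger inhibitor), compound 1 gives > 20000 nM, which is a limit of the assay and not a number. Compound 2 `COc1ccc(NC(=O)N[C@H]2CC[C@H](Oc3ccc(F)cc3)CC2)cc1` gives > 20000 nM in this assay, again a limit. Compound 3 `Cc1ccccc1NC(=O)N[C@H]1CC[C@H](Oc2ccc(F)cc2)CC1` gives > 20000 nM in this assay, also a limit. Within the data shown here, because of the limit of > 20000 nM in this assay, at which 3 of the 3 values shown sit, none of the pairwise steps can be sized: a step that the two limits leave unreadable from compound 1 to compound 2, a step that the two limits leave unreadable from compound 1 to compound 3 and a step that the two limits leave unreadable from compound 2 to compound 3 each run from one limit to another, so the series so far fixes only a floor for weakness and nothing about direction.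

Compound 4 `Cc1cccc(NC(=O)N[C@H]2CC[C@H](Oc3ccc(F)cc3)CC2)c1` is the next member. Its change from compound 1 is 3-methylphenyl in place of 2-methoxyphenyl on an amide-type nitrogen. All three measured steps bear on it, since each exchanges one small substituted phenyl for another on the same nitrogen, and none of them moved a compound off the limit. The expectation is therefore that compound 4 also sits at the limit, with no step beyond the scatter. For compound 4 the estimated value is 30000 nM, within a range from 15000 nM to 80000 nM. The corresponding step that the limit leaves unreadable from compound 1 to compound 4 is expected to be nominal only, since compound 1 itself is a limit.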

Compound 4, half-maximal inhibitory concentration: 14400 nM
For compound 4 the middle estimate is 2.1-fold (0.32 log units) above the measured one; measured number below the stated range.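

Compound 4 is the only member shown with a measured number rather than a limit in this assay, so 3-methylphenyl on the amide-type nitrogen gives the series its one value that is not a limit. Against the other three compounds, the comparison yields only floors: an at least 1.3-fold lower number from compound 1 to compound 4 (0.14 log units; that floor lies within the scatter) and an at least 1.3-fold lower number from compound 3 to compound 4 (0.14 log units; that floor lies within the scatter) and also an at least 1.3-fold lower number from compound 2 to compound 4 (0.14 log units; that floor lies within the scatter) are all that can be read for this exchange of one small substituted phenyl for another. Among these compounds, no step of real size is established for this change at this position, and the steps among compounds 1, 2 and 3 remain unreadable, because the comparisons rest on an assay limit: the limit of > 20000 nM in this assay, at which 3 of the 4 values shown sit.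

As far as these compounds go, whether moving the methyl group from 2-methylphenyl to 3-methylphenyl truly lowers the number remains open, as the step between compound 3 and compound 4 gives only a floor that does not clear the scatter. Also open, from the compounds shown here alone, is whether a different group on the same nitrogen, such as an aminophenyl, a carboxyphenyl or a longer alkyl chain, would shift the number beyond the scatter.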